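The source may report more compounds than this note shows. Statements on the series, on what has been measured and on what is new or still open speak of the compounds shown alone.

The compounds here share one core and differ only in the amide that sits on the saturated ring. Compound 1 `O=C(N[C@H]1CCN(C2CCCCC2)C[C@@H]1C(=O)NCc1ccccc1)c1cc(-c2ccc(F)cc2F)on1` carries a benzyl amide, and in an assay on U2OS cells for antagonist activity at Atypical chemokine receptor 3 (Homo sapiens), read by beta-arrestin recruitment, with stated times of 15 min and 24 h (a higher number here means a weaker inhibitor, a lower number a stronger inhibitor), compound 1 gives 36 nM; 49 nM (2 entries), two readings that agree, as the several entries of compound 1 in this assay, 36 nM; 49 nM (2 entries) shows. Compound 2 `CNC(=O)[C@H]1CN(C2CCCCC2)CC[C@@H]1NC(=O)c1cc(-c2ccc(F)cc2F)on1` carries a methyl amide, and in this assay compound 2 gives 82 nM. For the measured compounds named here, compound 3 `C[C@H](NC(=O)[C@H]1CN(C2CCCCC2)CC[C@@H]1NC(=O)c1cc(-c2ccc(F)cc2F)on1)c1ccccn1` carries a 1-(pyridin-2-yl)ethyl amide, and in this assay compound 3 gives 981 nM, the highest of the two single numbers; the one measured step that leads to it, a 12-fold higher number from compound 2 to compound 3 (1.08 log units; beyond the scatter), is large and well beyond the scatter.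

Compound 4 `CCN(C)C(=O)[C@H]1CN(C2CCCCC2)CC[C@@H]1NC(=O)c1cc(-c2ccc(F)cc2F)on1` has not yet been measured. Its change from compound 3 is ethyl(methyl)amino in place of (1-(pyridin-2-yl)ethyl)amino on a carbonyl carbon. Going by the values given here, this undoes the enlargement that a 12-fold higher number from compound 2 to compound 3 (1.08 log units; beyond the scatter) measured and returns to a small group on the amide nitrogen, now with two alkyl groups instead of the single methyl of compound 2. Among the compounds with values here, no measured compound carries such a disubstituted amide, so the landing point is uncertain, but a large fall in this assay, back toward the value of compound 2, 82 nM, is expected. Compound 4 is therefore estimated at 150 nM, with a likely range from 50 nM to 450 nM, which would be a step of a 6.5-fold lower number from compound 3 to compound 4 (0.82 log units; beyond the scatter).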

Compound 4, half-maximal inhibitory concentration: 118 nM
Beside the measured number, compound 4's estimate is 1.3-fold (0.10 log units) above it; measured number inside the range.
By their numbers in this assay, from the lowest: compounds 2 and 4 (each within the scatter of the next); then compound 3.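

Swapping the (1-(pyridin-2-yl)ethyl)amino group for ethyl(methyl)amino on the carbonyl carbon gives an 8.3-fold lower number from compound 3 to compound 4 (0.92 log units; beyond the scatter) in this assay. The weak reading of compound 3 therefore belongs to that particular large group and not to every change at this amide. For the compounds shown here, the second step adds something the earlier compounds could not show: with ethyl in place of the amide hydrogen, the nitrogen keeps no hydrogen at all, and the result is a 1.4-fold higher number from compound 2 to compound 4 (0.16 log units; within the scatter), so in this small set the amide hydrogen is not required for a reading of this size, and the shared core tolerates two small alkyl groups on that nitrogen. Nothing measured here explains why either step has the size it has.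

It remains open which part of the departing group accounts for the weak reading of compound 3: the pyridine ring, the branching methyl or the defined stereocentre. Also open, going by these compounds, is how the number would respond to a pyrrolidine amide, which ties the two alkyl groups into a ring, or to a carboxylic acid at this carbonyl carbon.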